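Allyl to benzyl on the chromane oxygen: effect on activity

The compounds below may be only part of what the source reports. "The series", "measured", "known", "first", "only" and "open" are said of these compounds alone.

Measured compounds:
- compound 1 `C=CCOc1c(C)c(C)c2c(c1C)CCC(C)(COc1ccc(/C=C3\SC(=O)NC3=O)cc1)O2` gives 2% in a functional assay on MCF7 cells (Homo sapiens), tested at 7.5 uM; a lower number here means a stronger effect, a higher number a weaker effect of the compound at the concentration tested
- compound 2 `C=CCOc1c(C)c(C)c2c(c1C)CCC(C)(COc1ccc(/C=C3\SC(=O)NC3=O)cc1C)O2` gives 8% in this assay
- compound 3 `C=CCOc1c(C)c(C)c2c(c1C)CCC(C)(COc1ccc(/C=C3\SC(=O)NC3=O)cc1OCC)O2` gives 75% in this assay

Compound 1 stands lowest of the three numbers in this assay. Compound 2 lies nearest, with a number 6 percentage points higher from compound 1 to compound 2 (within the scatter), while compound 3 lies furthest, with a number 73 percentage points higher from compound 1 to compound 3 (beyond the scatter). Between the two substituted analogues the step is a number 67 percentage points higher from compound 2 to compound 3 (beyond the scatter).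

Compound 4 `Cc1c(C)c2c(c(C)c1OCc1ccccc1)CCC(C)(COc1ccc(/C=C3\SC(=O)NC3=O)cc1)O2` differs from compound 1 in one place: phenyl in place of vinyl on a saturated chain carbon bound to an oxygen on an aromatic ring. The measured steps all alter the other aromatic ring, the one carrying the thiazolidinedione, and not the saturated chain carbon bound to an oxygen on the aromatic ring of the shared core. None of them therefore bears directly on this change, and the data give no guide to its size or direction. Compound 4 is expected to stay near compound 1, so its estimate is 12% with a range from 0% to 45%, meaning an expected step of a number 10 percentage points higher from compound 1 to compound 4 (within the scatter).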

Compound 4, a percentage reported as activity, at one concentration (the size of the read-out at that concentration, not a potency): 12%
Compound 4: middle estimate and measured number agree at the digits printed; measured number inside the range.
By their numbers in this assay, from the lowest: compounds 1, 2 and 4 (each within the scatter of the next); then compound 3.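

In this assay, replacing allyl with benzyl on the oxygen of the shared core gives a number 10 percentage points higher from compound 1 to compound 4 (within the scatter). This shows that this position accepts a phenyl in place of a vinyl, a six-membered aromatic ring where two carbons stood, with no read-out difference that can be told apart from the scatter. Within the data shown here, the only large steps so far therefore remain those on the other aromatic ring, and no measured evidence is at hand to explain why the larger group is accepted here.

Going by these compounds, it remains open whether a phenyl carrying a carboxylic acid or an amine, or a longer saturated chain such as hexyl, would also be accepted on this oxygen. On these data alone, it is also open whether the ethoxy group of compound 3 would have as large an effect on the benzyl compound 4.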